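A Bromo Analogue Judged Against Its Chloro and Hydrogen Kin

A few compounds are considered here, and "the series" means these few. Any claim that something is new, unique, unknown or untested is made for them only; others in the source may bear on it.

Compound 3 `Fc1cccc(F)c1Cc1cnc(Nc2ccc(Oc3cccnc3)cc2)o1` is the reference point. For the measured compounds named here, in an ADME assay on MT2 cells (Homo sapiens) for cytotoxicity, read by MTT assay (on this read-out higher numbers stand for lower toxicity in this test and lower numbers for higher toxicity in this test), compound 3 gives 22000 nM, which is the higher of the two plain numbers measured so far. Its nearest neighbour is compound 1 `Fc1cccc(F)c1Cc1cnc(Nc2ccc(Oc3cccnc3)c(Cl)c2)o1`, which in this assay gives 16000 nM; the step of a 1.4-fold higher number from compound 1 to compound 3 (0.14 log units; within the scatter) is too small to count. Compound 2 `O=c1ncccn1SCCc1ccc(Nc2ncc(Cc3c(F)cccc3F)o2)cc1` in this assay reaches only the limit > 100000 nM, so it gives no number. The step of an at least 4.5-fold lower number from compound 2 to compound 3 (0.65 log units; beyond the scatter) is therefore read from a limit (the limit of > 100000 nM in this assay, at which 1 of the 3 values shown sits).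

Compound 4 `Fc1cccc(F)c1Cc1cnc(Nc2ccc(Oc3cccnc3)c(Br)c2)o1` differs from compound 3 by bromo in place of hydrogen on an aromatic carbon. Going by the values given here, the one measured step that speaks to this place, from chloro to hydrogen, stayed within the scatter, so a bromo at the same position is expected to change little as well. The expected step of a 1.2-fold lower number from compound 3 to compound 4 (0.09 log units; within the scatter) is thus no more than scatter. Compound 4 is estimated to give 18000 nM in this assay, with a likely range from 8000 nM to 40000 nM.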

Compound 4, half-maximal cytotoxic concentration: 7500 nM
Compound 4: middle estimate off by 2.4-fold (0.38 log units), on the high side, outside the stated range (below it).
By their numbers in this assay, from the lowest: compound 4; then compounds 1 and 3 (each within the scatter of the next). At a limit, above all of these: compound 2.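

In this assay this position no longer looks silent: the step of a 2.9-fold lower number from compound 3 to compound 4 (0.47 log units; beyond the scatter) comes with bromo in place of hydrogen, and a lower number here stands for higher toxicity in this test. The step of a 2.1-fold lower number from compound 1 to compound 4 (0.33 log units; beyond the scatter) shows that bromo also parts from chloro at this carbon, whereas the step of a 1.4-fold higher number from compound 1 to compound 3 (0.14 log units; within the scatter) did not separate chloro from hydrogen. Among these three compounds, then, the atom on this aromatic carbon can matter, and only bromo stands apart from the other two.

As far as these compounds go, whether fluoro, methyl or an amine at the same carbon would stay with chloro and hydrogen or move with bromo remains open. Nothing in the evidence at hand bears on why bromo gives this result.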